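Bicyclic amide stereoisomer in the chloro-aryl oxadiazole azetidine series

The source may report more compounds than this note shows. Statements on the series, on what has been measured and on what is new or still open speak of the compounds shown alone.

Measured so far:
compound 1, `CC1CCCC(C(=O)N2CC(c3nc(-c4cccc(Cl)c4)no3)C2)C1`, 410 nM
compound 2, `O=C(c1ccccc1F)N1CC(c2nc(-c3cccc(Cl)c3)no2)C1`, > 10000 nM
compound 3, `O=C([C@H]1CC2CCC1C2)N1CC(c2nc(-c3cccc(Cl)c3)no2)C1`, 74 nM

Within an assay on HEK293 cells for positive allosteric modulation of metabotropic glutamate receptor 5 (Homo sapiens), read by FLIPR (on this read-out lower numbers stand for an effect already at smaller amounts and higher numbers for an effect only at larger amounts of compound), compound 3 holds the lowest number of the two numbers given; compound 1 sits nearest, with a 5.5-fold lower number from compound 1 to compound 3 (0.74 log units; beyond the scatter) separating them. Compound 2 reports only a limit, (the limit of > 10000 nM in this assay, at which 1 of the 3 values shown sits), and not a number. The replacement of the six-membered saturated ring by the bicyclic group on the carbonyl carbon therefore gave a 5.5-fold lower number from compound 1 to compound 3 (0.74 log units; beyond the scatter), while the aromatic amide was weaker by an at least 24-fold higher number from compound 1 to compound 2 (1.38 log units; beyond the scatter) and an at least 130-fold lower number from compound 2 to compound 3 (2.13 log units; beyond the scatter).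

Compound 4, `O=C([C@@H]1CC2CCC1C2)N1CC(c2nc(-c3cccc(Cl)c3)no2)C1`, is the next compound for this assay. Against compound 3 the change is the two compounds have the same atoms and bonds; at least one stereo element is drawn with a configuration in one of them and without one in the other: 1 of 3 stereo elements differ; a stereocentre at a saturated ring carbon is drawn S in compound 3 and R in compound 4. Going by the values given here, none of the measured steps concerns a change of configuration; all three exchange whole groups on the carbonyl carbon, so none bears directly on this step. What is known is that the bicyclic amide of compound 3 carries the series' lowest number, and a single inverted stereocentre can leave potency unchanged or shift it in either direction. With no measured guide, the expectation is a modest move toward a higher number, a 5.4-fold higher number from compound 3 to compound 4 (0.73 log units; beyond the scatter), with wide uncertainty. Compound 4 is thus estimated at 400 nM, within 80 nM to 4000 nM.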

Compound 4, half-maximal effective concentration: 98 nM
Compound 4: the middle estimate sits 4.1-fold (0.61 log units) above what was measured; the range from low to high includes it.
By their numbers in this assay, from the lowest: compounds 3 and 4 (each within the scatter of the next); then compound 1. At a limit, above all of these: compound 2.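

In this assay, going by these compounds alone, the change from S to R at the saturated ring carbon gives a 1.3-fold higher number from compound 3 to compound 4 (0.12 log units; within the scatter), so this inversion has no effect beyond the scatter, something the earlier steps, all exchanges of whole groups, could not show. The advantage of the bicyclic group over the 3-methylcyclohexyl group therefore does not depend on the configuration at this one carbon, as a 4.2-fold lower number from compound 1 to compound 4 (0.62 log units; beyond the scatter) stands with a 5.5-fold lower number from compound 1 to compound 3 (0.74 log units; beyond the scatter), and the 2-fluorophenyl amide remains far removed, with an at least 100-fold lower number from compound 2 to compound 4 (2.00 log units; beyond the scatter). The value for compound 2 is a limit and not a number, so that last step is only a bound: the limit of > 10000 nM in this assay, at which 1 of the 4 values shown sits.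

The comparison of compounds 3 and 4 therefore cannot be read as one between two fully defined forms, and the other stereo elements remain unresolved: the fact that one of compounds 3 and 4 is drawn with a defined configuration and the other without, at the place where they differ. Also open, as far as these compounds go, is whether the tolerance seen here extends to other groups on the carbonyl carbon, such as an amine or a carboxylic acid on the bicyclic group, or to a change on the chlorophenyl group, such as a nitrile in place of the chlorine.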